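From a sulfanyl to a sulfonyl side group

A few compounds are considered here, and "the series" means these few. Any claim that something is new, unique, unknown or untested is made for them only; others in the source may bear on it.

In a functional assay on DU-145 cells (Homo sapiens) for inhibition, read by trypan blue exclusion, with a stated time of 96 h (a lower number here means a stronger inhibitor of growth, a higher number a weaker inhibitor of growth), compound 3 (`CCOc1ccc(/C=C(/Sc2ccccc2Cl)C(=O)c2ccc(Cl)cc2)cc1OC`) gives 50000 nM, the highest of the three measured numbers, which makes it the weakest inhibitor of growth so far. Compound 1 (`CSc1ccc(/C=C(\C(=O)c2ccc(Cl)cc2)S(=O)(=O)Cc2ccc(C)cc2)cc1`) gives 10000 nM, and compound 2 (`Cc1ccc(CS(=O)(=O)/C(=C/c2cccc(Cl)c2Cl)C(=O)c2ccc(Cl)cc2)cc1`) gives 1000 nM.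

Compound 4 (`CCOc1ccc(/C=C(\C(=O)c2ccc(Cl)cc2)S(=O)(=O)Cc2ccc(C)cc2)cc1OC`) differs from compound 3 on a double-bonded chain carbon bound to a carbonyl carbon and a double-bonded chain carbon: (4-methylbenzyl)sulfonyl in place of (2-chlorophenyl)sulfanyl on a double-bonded chain carbon bound to a carbonyl carbon and a double-bonded chain carbon. For the measured compounds named here, the only measured step is a 10-fold lower number from compound 1 to compound 2 (1.00 log units; beyond the scatter). That step changes a different part of the molecule, so it shows how far the numbers can move here but does not test this swap. The better guide is that (4-methylbenzyl)sulfonyl is already present in two measured compounds. Compound 1 at 10000 nM and compound 2 at 1000 nM both carry it, and both lie well under compound 3 at 50000 nM. Going by the values given here, no measured pair isolates the swap, so the expectation remains rough.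

In this assay, the expected change is a 10-fold lower number from compound 3 to compound 4 (1.00 log units; beyond the scatter), an estimated move toward stronger inhibition that lies beyond the scatter. For compound 4 the estimated value is 5000 nM, with an expected range from 1000 nM to 20000 nM.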

Compound 4, concentration for 50% growth inhibition: 10000 nM
Compound 4: the middle estimate sits 2.0-fold (0.30 log units) below what was measured, and the stated range covers the measured number.
By their numbers in this assay, from the lowest: compound 2; then compounds 1 and 4 (each within the scatter of the next); then compound 3.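

In this assay, for the compounds shown here, putting (4-methylbenzyl)sulfonyl in place of (2-chlorophenyl)sulfanyl on a double-bonded chain carbon bound to a carbonyl carbon and a double-bonded chain carbon gives a 5.0-fold lower number from compound 3 to compound 4 (0.70 log units; beyond the scatter) as the first direct reading of this swap, with the rest of the molecule unchanged. With the sulfonyl side group held constant, 4-ethoxy-3-methoxyphenyl in place of 4-(methylsulfanyl)phenyl gives no change at the digits printed from compound 1 to compound 4 (within the scatter) in this pair, while 4-ethoxy-3-methoxyphenyl in place of 2,3-dichlorophenyl gives a 10-fold higher number from compound 2 to compound 4 (1.00 log units; beyond the scatter) in the other, so the group on the far end of the double bond can still move the number with this sulfonyl group in place. No supporting measurement is available to explain any of these steps.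

The swap alters both the sulfur link and the group it carries, so the compounds shown cannot separate those two changes; (4-methylbenzyl)sulfanyl or (2-chlorophenyl)sulfonyl at this position would pull them apart. Also open, as far as these compounds go, is how this position responds to a different kind of side group, such as one ending in an amine or a carboxylic acid.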